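The compounds below may be only part of what the source reports. "The series", "measured", "known", "first", "only" and "open" are said of these compounds alone.

Measured compounds in a functional assay on MDA-MB-231 cells (Homo sapiens) for cytotoxicity, read by MTT assay, with a stated time of 48 h; on this read-out lower numbers stand for stronger inhibition and higher numbers for weaker inhibition:

Compound 1 `O=C(/C=C/c1ccc2c(c1)B(O)OC2)c1cccnc1` gives 11400 nM.
Compound 2 `O=C(/C=C/c1ccc2c(c1)B(O)OC2)c1ccc(Br)cc1` gives 9500 nM.
Compound 3 `O=C(/C=C/c1ccc2c(c1)B(O)OC2)c1cccc(O)c1` gives 2700 nM.

Compound 1 has the highest number of the three. Its nearest neighbour is compound 2: a 1.2-fold lower number from compound 1 to compound 2 (0.08 log units; within the scatter). The furthest is compound 3: a 4.2-fold lower number from compound 1 to compound 3 (0.63 log units; beyond the scatter).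

Compound 4 `Nc1cccc(C(=O)/C=C/c2ccc3c(c2)B(O)OC3)c1` has not yet been measured. It differs from compound 1 in one place: 3-aminophenyl in place of pyridin-3-yl on a carbonyl carbon. Among the compounds with values here, the step that bears most on this change is the one to compound 3, where a ring with one hydrogen-bond donor and one acceptor likewise replaced pyridin-3-yl and gave a 4.2-fold lower number from compound 1 to compound 3 (0.63 log units; beyond the scatter). The step to compound 2, where 4-bromophenyl entered, stayed within the scatter: a 1.2-fold lower number from compound 1 to compound 2 (0.08 log units; within the scatter). Since 3-aminophenyl carries a donor and an acceptor as 3-hydroxyphenyl does, a modest move to lower numbers is expected, about the size seen with compound 3, or somewhat smaller. The expected step is a 2.9-fold lower number from compound 1 to compound 4 (0.45 log units; beyond the scatter). Compound 4 is expected to give 4000 nM, with a range from 1800 nM to 9000 nM.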

Compound 4, half-maximal inhibitory concentration: 3200 nM
Estimate against measurement, compound 4: 1.3-fold (0.10 log units) above; measured number inside the range.
By their numbers in this assay, from the lowest: compounds 3 and 4 (each within the scatter of the next); then compounds 2 and 1 (each within the scatter of the next).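

In this assay, 3-aminophenyl on the carbonyl carbon gives a 3.6-fold lower number from compound 1 to compound 4 (0.55 log units; beyond the scatter) and a 3.0-fold lower number from compound 2 to compound 4 (0.47 log units; beyond the scatter). Among these four compounds, the two rings carrying a hydrogen-bond donor, in compounds 3 and 4, now both stand apart from pyridin-3-yl and 4-bromophenyl, so the gain seen with compound 3 is no longer a single case. Amino in place of hydroxy on an aromatic carbon gives a 1.2-fold higher number from compound 3 to compound 4 (0.07 log units; within the scatter), so this assay does not separate the two groups, and no measurement here explains the gain.

As far as these compounds go, whether the donor hydrogen matters remains open, and an unsubstituted phenyl or a 3-methoxyphenyl ring would test this. From the compounds shown here alone, whether the location of the group on the ring matters also remains open, and 4-aminophenyl or 4-hydroxyphenyl would address that.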